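The source may hold more compounds than are shown below. What is called first, only, known or untested is meant among the compounds shown, and "the series" means these compounds.

Measured compounds:

Compound 1, `CC(NC(=O)/C=C/c1ccc(NC(=O)Nc2ccc(Cl)c(C(F)(F)F)c2)cc1)c1ccccc1`, in a functional assay on A-375 cells (Homo sapiens) for inhibition, read by MTT assay, with a stated time of 120 h (on this read-out lower numbers stand for stronger inhibition and higher numbers for weaker inhibition), gives 20800 nM.
Compound 2, `CC(NC(=O)c1ccc(-c2ccc(NC(=O)Nc3cc(C(F)(F)F)ccc3Cl)cc2)cc1)c1ccccc1`, in this assay gives 16900 nM.
Compound 3, `CC1CN(C(=O)/C=C/c2ccc(NC(=O)Nc3ccc(Cl)c(C(F)(F)F)c3)cc2)CC(C)O1`, in this assay gives only a limit of the assay, > 50000 nM.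

Compound 1 and compound 2 share the same terminal urea but differ in the middle of the molecule by more than a single group, and the difference between the two cores is not broken down here. Their two numbers lie within the usual scatter of each other, so no order between them can be read from these data.

Compound 3 is compound 1 after one change: 2,6-dimethylmorpholin-4-yl in place of (1-phenylethyl)amino on a carbonyl carbon. That change gave an at least 2.4-fold higher number from compound 1 to compound 3 (0.38 log units; beyond the scatter). The size of this step is only a lower bound, since compound 3 sits at the limit of > 50000 nM in this assay, at which 1 of the 3 values shown sits.

Compound 4, `CC1CN(C(=O)c2ccc(-c3ccc(NC(=O)Nc4cc(C(F)(F)F)ccc4Cl)cc3)cc2)CC(C)O1`, has not yet been measured. It is compound 2 after the corresponding change: 2,6-dimethylmorpholin-4-yl in place of (1-phenylethyl)amino on a carbonyl carbon. The place is not identical. In compound 1 the carbonyl carbon is joined to a double-bonded chain carbon, whereas in compound 2 it is joined to an aromatic carbon, so this is the same kind of change rather than the same change. The step from compound 2 to compound 4 is expected to be a 2.7-fold higher number from compound 2 to compound 4 (0.43 log units; beyond the scatter), resting on the weakening seen as an at least 2.4-fold higher number from compound 1 to compound 3 (0.38 log units; beyond the scatter) and on the starting point of compound 2 at 16900 nM. Compound 4 is therefore estimated at about 45000 nM, most likely between 20000 nM and 150000 nM, with a real chance that only a limit is reported.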

Compound 4, half-maximal inhibitory concentration: > 50000 nM
Compound 4 gave a limit, no number; the forecaster's own chance of this, stated with the estimate: 55%; middle value at least 1.1-fold (0.04 log units) from the limit.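

In this assay, placing 2,6-dimethylmorpholin-4-yl in place of (1-phenylethyl)amino on a carbonyl carbon gave an at least 2.9-fold higher number from compound 2 to compound 4 (0.47 log units; beyond the scatter), so the number rose beyond the scatter on this core too. Compound 4 gives only a limit of the assay, > 50000 nM, not a true number: the limit of > 50000 nM in this assay, at which 2 of the 4 values shown sit. For these two pairs, the change carries over in direction, from a carbonyl carbon joined to a double-bonded chain carbon to one joined to an aromatic carbon, but this does not show that its size carries over, and two pairs cannot establish a rule for the whole series: the same change on two cores in this assay, an at least 2.4-fold higher number (0.38 log units; beyond the scatter) from compound 1 to compound 3 and an at least 2.9-fold higher number (0.47 log units; beyond the scatter) from compound 2 to compound 4; the limit leaves it open whether they differ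

The change removes one six-membered aromatic ring of carbon only and a hydrogen-bond donor, and brings in a non-aromatic ring with 2 hetero atoms, all in a single step, so the compounds shown leave open which of these differences matters. A benzylamino group or an unsubstituted morpholin-4-yl group on the same carbonyl carbon would help to separate these differences, and a stronger starting compound would be needed for the full size of the step to be read as a number rather than a limit.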